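Swapping phenyl for tert-butyl in a growth inhibitor

This account rests on a few compounds, and the source may have more. Where it says the series, first, only, none or still open, it means among the compounds named here.

For the measured compounds named here, in a functional assay on A549 cells (Homo sapiens) for inhibition, read by sulforhodamine B assay, with a stated time of 48 h (on this read-out higher numbers stand for weaker inhibition of growth and lower numbers for stronger inhibition of growth), compound 2 (`c1ccc(-c2nc3ncccn3c2CN2CCCCC2)cc1`) gives 260 nM, the lowest of the two numbers so far. Compound 1 (`Oc1ccc(-c2nc3ncccn3c2CN2CCCCC2)cc1`), which carries a hydroxy on its phenyl, gives 6890 nM. Compound 3 (`CC(C)(C)c1nc2ncccn2c1CN1CCCCC1`) has tert-butyl in place of phenyl on an aromatic carbon of the core of compound 2: tert-butyl in place of phenyl on an aromatic carbon. Going by the values given here, only one measured step bears on this change: a 27-fold lower number from compound 1 to compound 2 (1.42 log units; beyond the scatter), a large step beyond the scatter. Among the compounds with values here, it shows that the number can move strongly with a change on this phenyl, but no measured compound lacks the phenyl altogether, so the evidence is indirect. On the strength of that step alone, a sizeable move towards weaker inhibition is expected, and the estimated step is a 9.6-fold higher number from compound 2 to compound 3 (0.98 log units; beyond the scatter). For compound 3 the expected value is 2500 nM, within an estimated range of 500 nM to 12000 nM.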

Compound 3, concentration for 50% growth inhibition: 330 nM
Beside the measured number, compound 3's estimate is 7.6-fold (0.88 log units) above it; the whole stated range lies above it.
By their numbers in this assay, from the lowest: compounds 2 and 3 (each within the scatter of the next); then compound 1.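

In this assay the swap at this aromatic carbon of the five-membered ring gives a step within the scatter (a 1.3-fold higher number from compound 2 to compound 3 (0.10 log units; within the scatter)), so tert-butyl, which has no ring, and phenyl cannot be told apart here, and an aromatic ring at this place is not needed to keep the number low. The step (a 21-fold lower number from compound 1 to compound 3 (1.32 log units; beyond the scatter)) is large and sets compound 1 apart from compound 3 as well as from compound 2, so among these compounds the high number goes with 4-hydroxyphenyl alone. Nothing shown accounts for why phenyl and tert-butyl read alike. The compounds shown leave open whether methyl or a bare hydrogen at this carbon would keep the number. They also leave open what an amine, a carboxylic acid or a longer chain would do here.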